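The source may hold more compounds than are shown below. What is called first, only, known or untested is meant among the compounds shown, and "the series" means these compounds.

Measured so far in an ADME assay on microsomes from liver (Mus musculus) for metabolic stability, with a stated time of 10 min; on this read-out lower numbers stand for a less stable compound and higher numbers for a more stable compound:

compound 1 `C[C@]1(C(=O)N2CC[C@](c3ccc(C(F)(C(F)(F)F)C(F)(F)F)cc3)(S(=O)(=O)c3ccc(F)cc3)C2)CC[C@H](C(=O)O)CC1`: in this assay compound 1 gives 95%
compound 2 `COC[C@]1(C(=O)N2CC[C@](c3ccc(C(F)(C(F)(F)F)C(F)(F)F)cc3)(S(=O)(=O)c3ccc(F)cc3)C2)CC[C@H](C(=O)O)CC1`: in this assay compound 2 gives 88%

Compound 1 holds the highest of the two numbers in this assay; its nearest neighbour is compound 2, and the step of a number 7 percentage points lower from compound 1 to compound 2 (within the scatter) is within the scatter, so the two are not ordered.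

Compound 3 `O=C(N1CC[C@](c2ccc(C(F)(C(F)(F)F)C(F)(F)F)cc2)(S(=O)(=O)c2ccc(F)cc2)C1)C1(CO)CCS(=O)(=O)CC1` is not yet measured in this assay. It differs from compound 1 by 4-(hydroxymethyl)-1,1-dioxothian-4-yl in place of 4-carboxy-1-methylcyclohexyl on a carbonyl carbon. Among the compounds with values here, no measured step bears directly on this change: the only step in this assay, a number 7 percentage points lower from compound 1 to compound 2 (within the scatter), concerns a different place on the shared core and was within the scatter. The change in compound 3 exchanges the whole ring and its substituents, so the range of the estimate is set wide. For compound 3 the step of a number 15 percentage points lower from compound 1 to compound 3 (beyond the scatter) is expected, with some loss beyond the scatter possible. For compound 3 the estimate is 80%, with a range from 55% to 97%.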

Compound 3, percent of the compound remaining: 31%
For compound 3 the middle estimate is 49 percentage points above the measured one, outside the stated range (below it).
By their numbers in this assay, from the lowest: compound 3; then compounds 2 and 1 (each within the scatter of the next).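

In this assay, 4-(hydroxymethyl)-1,1-dioxothian-4-yl in place of 4-carboxy-1-methylcyclohexyl on the carbonyl carbon gives a number 64 percentage points lower from compound 1 to compound 3 (beyond the scatter). In place of 4-carboxy-1-(methoxymethyl)cyclohexyl, the same group gives a number 57 percentage points lower from compound 2 to compound 3 (beyond the scatter), so this position is sensitive to exchange of the whole group, which the step between the two earlier compounds, a number 7 percentage points lower from compound 1 to compound 2 (within the scatter), gave no sign of. Nothing measured here accounts for the loss.

This exchange alters the ring, the carboxy group and the chain on the ring carbon all at once, so the part that carries the loss remains unassigned. Open questions are how a 1,1-dioxothian ring bearing a carboxylic acid would behave, and how a cyclohexyl ring bearing hydroxymethyl with the carboxylic acid kept would behave.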